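The compounds below may be only part of what the source reports. "The series", "measured", "known", "first", "only" and "open" are said of these compounds alone.

Compound 1 `Nc1cccc2c(-c3cccc(NC(=O)c4cc(Cl)cc(C(F)(F)F)c4)c3)ccnc12` and compound 2 `Nc1cccc2c(-c3cccc(NC(=O)c4cc(C(F)(F)F)cc(C(F)(F)F)c4)c3)ccnc12` share one core. In a functional assay on A375P cells (Homo sapiens) for antiproliferative activity, read by MTT assay, with a stated time of 48 h (a higher number here means a weaker inhibitor, a lower number a stronger inhibitor), compound 1 gives 18500 nM and compound 2 gives 3400 nM. The change between them is trifluoromethyl in place of chloro on an aromatic carbon, and it brought a 5.4-fold lower number from compound 1 to compound 2 (0.74 log units; beyond the scatter). Compound 3 `CC(=O)Nc1cccc2c(-c3cccc(NC(=O)c4ccc(Cl)cc4C(F)(F)F)c3)ccnc12` carries a different core from compound 1; the difference between the two cores is not broken down here. In this assay compound 3 gives only a limit, > 20000 nM, which is the limit of > 20000 nM in this assay, at which 1 of the 3 values shown sits. Compound 4 `CC(=O)Nc1cccc2c(-c3cccc(NC(=O)c4ccc(C(F)(F)F)cc4C(F)(F)F)c3)ccnc12` is not yet measured and differs from compound 3 by trifluoromethyl in place of chloro on an aromatic carbon. This is the same kind of change as that from compound 1 to compound 2, though the surroundings differ: in compound 1 the place is meta to a large group and meta to a trifluoromethyl group, whereas in compound 3 it is meta to a trifluoromethyl group and para to a large group. Resting on the measured step of a 5.4-fold lower number from compound 1 to compound 2 (0.74 log units; beyond the scatter), the expected step is an at least 2.0-fold lower number from compound 3 to compound 4 (0.30 log units; that floor lies within the scatter). For compound 4 the estimate in this assay is 10000 nM, between 3000 nM and 30000 nM.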

Compound 4, half-maximal inhibitory concentration: 10100 nM
Beside the measured number, compound 4's estimate is 1.0-fold (0.00 log units) below it, and the stated range covers the measured number.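

In this assay, trifluoromethyl in place of chloro gives an at least 1.9-fold lower number from compound 3 to compound 4 (0.29 log units; that floor lies within the scatter), so on this second core a real gain is not firmly shown, though nothing goes against one. Whether the change carries over from one core to the other at the same size stays unsettled: the same change on two cores in this assay, a 5.4-fold lower number (0.74 log units; beyond the scatter) from compound 1 to compound 2 and an at least 1.9-fold lower number (0.29 log units; that floor lies within the scatter) from compound 3 to compound 4; the limit leaves it open whether they differ. The value of compound 3 is a limit, not a number, and so the second step has only a floor: the limit of > 20000 nM in this assay, at which 1 of the 4 values shown sits.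

The compounds shown leave open how other groups in that place, such as a nitrile, an amine or a carboxylic acid, would compare with chloro and trifluoromethyl. They also give no direct comparison of the two cores carrying identical groups.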